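Demethylation of one aryl methoxy group in pyrazine hydrazones

The source may hold more compounds than are shown below. What is called first, only, known or untested is meant among the compounds shown, and "the series" means these compounds.

Within the data shown here, compound 2 `COc1ccc(/C=N/NC(=O)c2cnccn2)cc1OC` gives 49.6% in a functional assay on the whole organism (strain Swiss) for inhibition, with Mus musculus as the target, read by paw edema, with stated times of 40 min and 30 min, at a dose of 100 umol/kg by the oral route (a lower number here means less inhibition, a higher number more inhibition at the dose given (going by the name of the read-out)), the lower of the two numbers measured so far. Among the measured compounds shown here, compound 1 `COc1cc(/C=N/NC(=O)c2cnccn2)ccc1O` gives 63.5% in this assay, and the step from the free hydroxy to its methyl ether, a number 13.9 percentage points lower from compound 1 to compound 2 (beyond the scatter), lies beyond the scatter and is the only step measured.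

Compound 3 `COc1ccc(/C=N/NC(=O)c2cnccn2)cc1O` is the next candidate. It differs from compound 2 by hydrogen in place of methyl on an oxygen on an aromatic ring, the same kind of change seen between compound 1 and compound 2, in the opposite direction and at the other oxygen of the ring. For the measured compounds named here, the measured step of a number 13.9 percentage points lower from compound 1 to compound 2 (beyond the scatter) is therefore the only guide, and on its basis a modest rise in this assay is expected for compound 3, in size close to the reverse of that step, about a number 10.4 percentage points higher from compound 2 to compound 3 (beyond the scatter), allowing for the different oxygen involved. Compound 3 is thus estimated at 60% in this assay, within a range of 48% to 72%.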

Compound 3, a percentage reported as inhibition, in the whole organism at one dose (the size of the read-out at that dose, not a potency): 27%
For compound 3 the middle estimate is 33 percentage points above the measured one; the whole stated range lies above it.
By their numbers in this assay, from the lowest: compound 3; then compound 2; then compound 1.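

In this assay the change from methoxy to hydroxy at this oxygen gives a number 22.6 percentage points lower from compound 2 to compound 3 (beyond the scatter) and runs opposite to the other oxygen of the ring, where placing methyl on the free hydroxy of compound 1 gives a number 13.9 percentage points lower from compound 1 to compound 2 (beyond the scatter) as the printed step. The effect of this change therefore depends on which oxygen carries it, and a step read at one oxygen does not transfer to the other in these compounds. Nothing on hand explains this difference between the two oxygens.

Still open, on these data alone, is whether the methoxy at this oxygen is specifically required, or whether a longer chain such as ethoxy would serve there as well. Also open, as far as these compounds go, is how an amine or a carboxylic acid at this place would compare with the hydroxy of compound 3.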